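The source may report more compounds than this note shows. Statements on the series, on what has been measured and on what is new or still open speak of the compounds shown alone.

Measured compounds:
Compound 1 `O=C(O)CC1COc2cc(OCc3ncc(-c4ccccc4)o3)ccc21` gives 2.34% in a functional assay on CHO cells for agonist activity at Free fatty acid receptor 1 (Homo sapiens), read by FLIPR and calcium flux, tested at 100 nM; a lower number here means a weaker effect, a higher number a stronger effect of the compound at the concentration tested.
Compound 2 `O=C(O)CC1COc2cc(OCc3nc(-c4ccccc4)cs3)ccc21` gives 0.16% in this assay.
Compound 3 `Cc1nc(-c2ccsc2)sc1COc1ccc2c(c1)OCC2CC(=O)O` gives 56.5% in this assay.

Among these three compounds, compound 3 stands highest; the values of compound 1 and compound 2 lie far below it, and both gaps are well beyond the usual scatter of this assay. Among the measured compounds shown here, compound 1 and compound 2 share the same acid-bearing core with compound 3 but carry different aromatic groups on different heteroaromatic rings, so no single-point step between the measured compounds can be drawn.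

Compound 4 `Cc1nc(-c2cccc(F)c2)sc1COc1ccc2c(c1)OCC2CC(=O)O` has not yet been measured. It differs from compound 3 in one place: 3-fluorophenyl in place of thiophen-3-yl on an aromatic carbon. For the measured compounds named here, no measured pair isolates this exchange, so the expectation rests on the position of compound 3 alone. The step from compound 3 to compound 4 is expected to be a modest decrease, a number 14.5 percentage points lower from compound 3 to compound 4 (beyond the scatter), possibly small enough to fall within the scatter. For compound 4 the estimated value in this assay is 42%, with a range from 12% to 68%.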

Compound 4, a percentage reported as activity, at one concentration (the size of the read-out at that concentration, not a potency): 56.9%
Compound 4: middle estimate off by 14.9 percentage points, on the low side; the measured number falls inside the stated range.
By their numbers in this assay, from the lowest: compounds 2 and 1 (each within the scatter of the next); then compounds 3 and 4 (each within the scatter of the next).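

In this assay, placing 3-fluorophenyl instead of thiophen-3-yl on the aromatic carbon next to the ring nitrogen and next to the ring sulfur gives a number 0.4 percentage points higher from compound 3 to compound 4 (within the scatter). Among the compounds shown here, this is the first exchange between measured compounds that differ in one place, and it shows that this position can carry either a five-membered aromatic ring with a hetero atom or a six-membered aromatic ring of carbon only without the read-out separating the two. The data shown offer no explanation for this equivalence.

The read-out comes from one concentration. At other concentrations the effects of the two compounds may still differ. Going by these compounds, whether a plain phenyl, a pyridine ring, or a phenyl bearing a methoxy group or a carboxylic acid would fit this position equally well also remains open.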